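Pyrazole amine series: cytotoxicity and the aryl swap

The compounds below may be only part of what the source reports. "The series", "measured", "known", "first", "only" and "open" are said of these compounds alone.

Measured so far:
- compound 1 `Cc1ccccc1-c1nn(C(C)C)cc1CNCCN1CCN(C)CC1`: > 20000 nM
- compound 2 `CN1CCN(CCNCc2cn(-c3ccc(C(F)(F)F)cc3)nc2-c2ccc(C(F)(F)F)cc2)CC1`: 1500 nM

Among the compounds with values here, in an ADME assay on Huh-7 cells (Homo sapiens) for cytotoxicity (a lower number here means that less compound is tolerated, a higher number that more compound is tolerated), compound 2 gives 1500 nM, the only number in this set. Compound 1 gives > 20000 nM in this assay, which is a limit of the assay and not a number. The two compounds differ in more than one place, so their values are read side by side only: compound 2 sits at a number, compound 1 at the limit (the limit of > 20000 nM in this assay, at which 1 of the 2 values shown sits).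

Compound 3 `Cc1ccccc1-c1nn(-c2ccc(C(F)(F)F)cc2)cc1CNCCN1CCN(C)CC1` is not yet measured. It differs from compound 2 by 2-methylphenyl in place of 4-(trifluoromethyl)phenyl on an aromatic carbon. Compound 1 carries the same 2-methylphenyl and sits at the limit, whereas compound 2 sits at a number, so for compound 3 a step toward more tolerated compound is expected, beyond the scatter but not certain to reach the limit. The expected step in this assay is a 3.3-fold higher number from compound 2 to compound 3 (0.52 log units; beyond the scatter). For compound 3 the estimate in this assay is 5000 nM, with a range from 1500 nM to 20000 nM.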

Compound 3, half-maximal cytotoxic concentration: 11000 nM
The estimate for compound 3 lay 2.2-fold (0.34 log units) below the measured number; the measured number falls inside the stated range.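

In this assay, the position on the aromatic carbon next to the ring nitrogen now has a reading in one place: 2-methylphenyl in place of 4-(trifluoromethyl)phenyl gives a 7.3-fold higher number from compound 2 to compound 3 (0.87 log units; beyond the scatter), with the 4-(trifluoromethyl)phenyl on the ring nitrogen held constant. On that ring nitrogen, 4-(trifluoromethyl)phenyl in place of isopropyl gives an at least 1.8-fold lower number from compound 1 to compound 3 (0.25 log units; that floor lies within the scatter), so this comparison sets only a floor that does not separate the two compounds beyond the scatter. Compound 1 remains at a limit of the assay, not a number: the limit of > 20000 nM in this assay, at which 1 of the 3 values shown sits.

The compounds shown do not separate the loss of the trifluoromethyl group from the arrival of the 2-methyl group, and an unsubstituted phenyl or a 4-methylphenyl on the same aromatic carbon would divide those two parts of the change. On these data alone, the size of the change on the ring nitrogen also stays open, as does the part played by the side chain, where a morpholine in place of the 4-methylpiperazine would test the amine end.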